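A few compounds are considered here, and "the series" means these few. Any claim that something is new, unique, unknown or untested is made for them only; others in the source may bear on it.

Working notes on the series. Compound 3 `O=S(=O)(c1cc(Cl)cc(Cl)c1)c1cnc2cc(F)ccc2c1-c1ccc(F)cc1` is measured in an ADME assay on microsomes from liver (Rattus norvegicus) for metabolic stability, tested at 2.5 uM (a higher number here means faster removal of the compound, a lower number slower removal), at 1.15 mL/min. Compound 1 `O=S(=O)(c1cc(Cl)cc(Cl)c1)c1cnc2cc(F)ccc2c1-c1ccc(Cl)cc1` gives 0.77 mL/min and compound 2 `O=S(=O)(c1cc(F)cc(F)c1)c1cnc2cc(F)ccc2c1-c1cccc(F)c1` gives 1.8 mL/min; compound 3 thus holds the second highest of the three numbers, its nearest neighbour being compound 1 and its furthest compound 2, both within the scatter. Within the data shown here, the only measured step, a 1.5-fold higher number from compound 1 to compound 3 (0.17 log units; within the scatter), is a change of a different kind. Compound 4 `O=S(=O)(c1cc(Cl)cc(Cl)c1)c1cnc2cc(F)ccc2c1-c1cccc(F)c1` differs from compound 3 by 3-fluorophenyl in place of 4-fluorophenyl on an aromatic carbon, set on an aromatic carbon opposite the ring nitrogen. Compound 2 also carries 3-fluorophenyl, and its number and that of compound 3 lie within the scatter of each other. Among the measured compounds shown here, no measured step bears directly on this change, so the expected step is a 1.1-fold higher number from compound 3 to compound 4 (0.05 log units; within the scatter), no larger than the scatter. Compound 4 is estimated at 1.3 mL/min, with a range of 0.7 mL/min to 2.4 mL/min.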

Compound 4, intrinsic clearance in a liver preparation (reported as CLH), per the amount of preparation that the assay uses: 1.53 mL/min
The estimate for compound 4 lay 1.2-fold (0.07 log units) below the measured number; low and high end bracket the measured number.
By their numbers in this assay, from the lowest: compounds 1, 3, 4 and 2 (each within the scatter of the next, the first and the last beyond it).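

In this assay, 3-fluorophenyl in place of 4-fluorophenyl on this aromatic carbon, opposite the ring nitrogen, gives a small step (a 1.3-fold higher number from compound 3 to compound 4 (0.12 log units; within the scatter)), so moving the fluorine shifts the number no more than the scatter. Two further single changes also stay within the scatter: 3,5-dichlorophenyl in place of 3,5-difluorophenyl on the sulfonyl sulfur (a 1.2-fold lower number from compound 2 to compound 4 (0.07 log units; within the scatter)) and 3-fluorophenyl in place of 4-chlorophenyl (a 2.0-fold higher number from compound 1 to compound 4 (0.30 log units; within the scatter)). Nothing available accounts for any of these steps. On these data alone, how an amine or a carboxylic acid on this phenyl would affect the number remains open.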